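The source may report more compounds than this note shows. Statements on the series, on what has been measured and on what is new or still open speak of the compounds shown alone.

Measured in a functional assay on DU-145 cells (Homo sapiens) for antiproliferative activity, read by MTT assay, with a stated time of 48 h; on this read-out lower numbers stand for stronger inhibition and higher numbers for weaker inhibition:
- Compound 1 `C/C(=C\CC/C(C)=C/CC[C@@H]1[C@@]2(C)CCC(=O)C(C)(C)[C@H]2CC[C@@]1(C)O)CC/C=C(\C)C(=O)OCc1cn(-c2ccc([N+](=O)[O-])cc2)nn1`: > 150000 nM, a limit
- Compound 2 `C/C(=C\CC/C(C)=C/CC[C@@H]1[C@@]2(C)CCC(=O)C(C)(C)[C@H]2CC[C@@]1(C)O)CC/C=C(\C)C(=O)OCc1cn(-c2ccccc2Br)nn1`: > 150000 nM, a limit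
- Compound 3 `COc1ccc(-n2cc(COC(=O)/C(C)=C/CC/C(C)=C/CC/C(C)=C/CC[C@@H]3[C@@]4(C)CCC(=O)C(C)(C)[C@H]4CC[C@@]3(C)O)nn2)cc1`: 135000 nM

Among these three, compound 3 alone has an actual number, 135000 nM. The rest of the series is defined by the limit of > 150000 nM in this assay, at which 2 of the 3 values shown sit.

Compound 4 `C/C(=C\CC/C(C)=C/CC[C@@H]1[C@@]2(C)CCC(=O)C(C)(C)[C@H]2CC[C@@]1(C)O)CC/C=C(\C)C(=O)OCc1cn(-c2ccc(C)cc2)nn1` has methyl in place of methoxy on an aromatic carbon, para to a large group: methyl in place of methoxy on an aromatic carbon.

The closest measured precedent is methoxy in place of nitro on an aromatic carbon, an at least 1.1-fold lower number from compound 1 to compound 3 (0.04 log units; that floor lies within the scatter). The aryl change an at least 1.1-fold lower number from compound 2 to compound 3 (0.04 log units; that floor lies within the scatter) gives the same reading, while a step that the two limits leave unreadable from compound 1 to compound 2 offers no usable size. With only these small floors to go on, no step beyond the scatter is expected in this assay, in either direction.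

The estimated step is a 1.1-fold higher number from compound 3 to compound 4 (0.03 log units; within the scatter). A result reported only as a limit would also be unsurprising. The expected value for compound 4 is 145000 nM, with an estimated range of 90000 nM to 230000 nM.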

Compound 4, half-maximal inhibitory concentration: > 150000 nM
Compound 4 ended at the assay's limit (the forecaster's own chance of this, stated with the estimate: 55%); middle value at least 1.0-fold (0.01 log units) from the limit.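

In this assay compound 4 gives > 150000 nM, which is a limit and not a number. The change from methoxy to methyl on this aromatic carbon, para to a large group, gives an at least 1.1-fold higher number from compound 3 to compound 4 (0.04 log units; that floor lies within the scatter), while the steps to compound 4 from compound 1 and from compound 2 cannot be read. Methyl therefore joins the 4-nitrophenyl of compound 1 and the 2-bromophenyl of compound 2 at the same limit, compound 3 remains the only compound with an actual number, and the series now reads: the limit of > 150000 nM in this assay, at which 3 of the 4 values shown sit.

Going by these compounds, how far compound 4 truly lies from compound 3 remains open. On these data alone, it is also open whether a hydroxyl, an amine or a carboxylic acid on this aromatic carbon would give a step beyond the scatter from compound 3.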